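From methylamino to piperidin-1-yl on compound 2

This account rests on a few compounds, and the source may have more. Where it says the series, first, only, none or still open, it means among the compounds named here.

In a functional assay on Ishikawa cells (Homo sapiens) for antiproliferative activity, read by CCK-8 assay, with a stated time of 48 h (a lower number here means a stronger inhibitor, a higher number a weaker inhibitor), compound 1 (`CNC(=O)/C=C/CN1CC(Oc2ccc(Oc3c(-c4ccc(F)cc4)sc4cc(O)ccc34)cc2)C1`) reads > 25000 nM, which is a limit of the assay and not a number. Compound 2 (`CNC(=O)/C=C/CNCCOc1ccc(Oc2c(-c3ccc(F)cc3)sc3cc(O)ccc23)cc1`) gives 15500 nM. Compound 3 (`C=CC(=O)N1CC(Oc2ccc(Oc3c(-c4ccc(F)cc4)sc4cc(O)ccc34)cc2)C1`) gives 12300 nM. Compound 2 therefore has one measured neighbour, at a 1.3-fold lower number from compound 2 to compound 3 (0.10 log units; within the scatter).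

Compound 4 (`O=C(/C=C/CNCCOc1ccc(Oc2c(-c3ccc(F)cc3)sc3cc(O)ccc23)cc1)N1CCCCC1`) carries piperidin-1-yl in place of methylamino on a carbonyl carbon. Among the compounds with values here, no measured step alters this group on its own. The steps available change other parts of the side chain: an at least 1.6-fold lower number from compound 1 to compound 2 (0.20 log units; that floor lies within the scatter), and an at least 2.0-fold lower number from compound 1 to compound 3 (0.30 log units; that floor lies within the scatter). None of these steps is shown to exceed the scatter, so they give no reason to expect a large shift in this assay. No step beyond the scatter is expected for this change, and no direction is favoured with confidence. The expected step is a 1.2-fold lower number from compound 2 to compound 4 (0.08 log units; within the scatter). Compound 4 is estimated at 13000 nM, with an expected range of 5500 nM to 25000 nM.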

Compound 4, half-maximal inhibitory concentration: 8430 nM
For compound 4 the middle estimate is 1.5-fold (0.19 log units) above the measured one; low and high end bracket the measured number.
By their numbers in this assay, from the lowest: compounds 4, 3 and 2 (each within the scatter of the next). At a limit, above all of these: compound 1.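

In this assay, within the data shown here, the first reading at this carbonyl carbon is a 1.8-fold lower number from compound 2 to compound 4 (0.26 log units; within the scatter). The side chain of compound 2 therefore takes piperidin-1-yl, a six-membered non-aromatic ring with no hydrogen-bond donor, in place of methylamino without a step beyond the scatter. Both ends of this step are numbers, unlike compound 1, the one compound held at a limit: the limit of > 25000 nM in this assay, at which 1 of the 4 values shown sits.

Open, as far as these compounds go, is how morpholin-4-yl, dimethylamino or a free carboxylic acid on the same carbonyl carbon would read, since a single replacement cannot separate the added ring from the lost amide hydrogen. Also open, from the compounds shown here alone, is whether piperidin-1-yl would read alike on the 1-(3-(methylcarbamoyl)prop-2-en-1-yl)azetidin-3-yl side chain of compound 1.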